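Solubility of compound 4 after the furan exchange

A few compounds are considered here, and "the series" means these few. Any claim that something is new, unique, unknown or untested is made for them only; others in the source may bear on it.

The measured compounds:
- compound 1, `FC(F)(F)c1ccc(-c2ccc3c(NCCCNCc4ccco4)ccnc3c2)cc1`, 32000 nM
- compound 2, `CCC(CC)c1ccc2c(NCCCNCc3ccco3)ccnc2c1`, 4200 nM
- compound 3, `COc1ccc(Oc2ccc3c(NCCCNCc4ccco4)ccnc3c2)cc1`, 14500 nM

In a physicochemical assay for solubility, with a stated time of 18 h, at pH 7.4 (a higher number here means a more soluble compound, a lower number a less soluble compound), compound 1 gives the highest of the three numbers. Its nearest neighbour is compound 3, with a 2.2-fold lower number from compound 1 to compound 3 (0.34 log units; beyond the scatter), and the furthest is compound 2, with a 7.6-fold lower number from compound 1 to compound 2 (0.88 log units; beyond the scatter); the step of a 3.5-fold higher number from compound 2 to compound 3 (0.54 log units; beyond the scatter) closes the triangle. All three measured steps change the group on an aromatic carbon of the shared core while the furan-bearing chain is kept the same.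

Compound 4, `COc1cccc(CNCCCNc2ccnc3cc(-c4ccc(C(F)(F)F)cc4)ccc23)c1O`, changes the other end: 2-hydroxy-3-methoxyphenyl in place of furan-2-yl on a saturated chain carbon bound to an amine nitrogen. Going by the values given here, no measured step touches this position, so the three steps bear on it only indirectly, by showing that single-group exchanges on this core move this assay by modest amounts. The entering group is larger and carries a hydrogen-bond donor where the furan had none. Among the compounds with values here, with no direct precedent, a step within or just beyond the scatter is expected, leaning lower, a 1.6-fold lower number from compound 1 to compound 4 (0.20 log units; within the scatter). Compound 4 is therefore estimated at 20000 nM, ranging from 7000 nM to 55000 nM.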

Compound 4, solubility: 32000 nM
Compound 4: the middle estimate sits 1.6-fold (0.20 log units) below what was measured; low and high end bracket the measured number.
By their numbers in this assay, from the lowest: compound 2; then compound 3; then compounds 1 and 4 (each within the scatter of the next).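

In this assay, putting 2-hydroxy-3-methoxyphenyl in place of furan-2-yl on a saturated chain carbon bound to an amine nitrogen gives no change at the digits printed from compound 1 to compound 4 (within the scatter). This is the only step shown at this position, and unlike the three steps on an aromatic carbon, all beyond the scatter, it leaves the read-out within the scatter. On the 4-(trifluoromethyl)phenyl compounds, then, this position takes the larger group with its hydrogen-bond donor without a measurable shift, although no supporting measurement is available to account for that result.

From the compounds shown here alone, it remains open whether a plain phenyl, a pyridine ring or a carboxylic acid at this position would give the same reading. Going by these compounds, it is also open whether this exchange would read the same on compound 2, which carries pentan-3-yl.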